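The source may report more compounds than this note shows. Statements on the series, on what has been measured and on what is new or still open speak of the compounds shown alone.

Compound 1 `Cc1ccc(/C=C/C[C@H]2C[C@@H]([C@@H](O)c3ccccc3)CO[C@@H]2c2ccccc2)cc1C`: 10000 nM
Compound 2 `COc1ccc(/C=C/C[C@H]2C[C@@H]([C@@H](O)c3ccc(OC)c(OC)c3)CO[C@@H]2c2ccc(OC)c(OC)c2)cc1OC`: 23800 nM

In a functional assay on HeLa cells (Homo sapiens) for cytotoxicity, read by WST assay, with a stated time of 48 h (on this read-out lower numbers stand for stronger inhibition and higher numbers for weaker inhibition), compound 1 gives 10000 nM, the lower of the two numbers. Compound 2 gives 23800 nM in this assay, a higher number, and the gap between the two lies beyond the scatter. Compound 3 `Oc1ccccc1/C=C/C[C@H]1C[C@@H]([C@@H](O)c2ccccc2)CO[C@@H]1c1ccccc1` keeps the shared core of compound 1 and differs from it in one place: 2-hydroxyphenyl in place of 3,4-dimethylphenyl on a double-bonded chain carbon bound to a double-bonded chain carbon. Among the measured compounds shown here, no measured pair shows this change, so its effect is unknown. The step of a 1.2-fold higher number from compound 1 to compound 3 (0.08 log units; within the scatter) is expected to be small, within the scatter or slightly toward a higher number. Compound 3 is therefore estimated at 12000 nM, between 4000 nM and 40000 nM.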

Compound 3, half-maximal inhibitory concentration: 21800 nM
Compound 3: middle estimate off by 1.8-fold (0.26 log units), on the low side; the range from low to high includes it.
By their numbers in this assay, from the lowest: compound 1; then compounds 3 and 2 (each within the scatter of the next).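

Measured in this assay the swap of 3,4-dimethylphenyl for 2-hydroxyphenyl on a double-bonded chain carbon bound to a double-bonded chain carbon gives a 2.2-fold higher number from compound 1 to compound 3 (0.34 log units; beyond the scatter) and so weaker inhibition. Among the compounds shown here, this is the first single change that can be read, and it shows that this position responds modestly to the group it carries. Nothing measured here explains the shift.

Still open, on these data alone, is whether the step comes from losing the two methyl groups or from gaining the hydroxyl. As far as these compounds go, it is also open whether an amine or a carboxylic acid on this ring would move the number lower or higher.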